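Methoxy to methyl: working notes on compound 4

The source may report more compounds than this note shows. Statements on the series, on what has been measured and on what is new or still open speak of the compounds shown alone.

Measured in a functional assay on M14 cells (Homo sapiens) for cytotoxicity; a higher number here means a weaker inhibitor of growth, a lower number a stronger inhibitor of growth:
compound 1 `COc1ccc(C2=C(c3cc(OC)c(OC)c(OC)c3)CC3CCCN3C2=O)cc1O`: > 100000 nM (a limit, not a number)
compound 2 `COc1ccc(C2=C(c3ccc(SC)cc3)CC3CCCN3C2=O)cc1C`: 200 nM
compound 3 `CSc1ccc(C2=C(c3ccc(F)c(F)c3)C(=O)N3CCCC3C2)cc1`: 300 nM

Compound 1 gives > 100000 nM, which is a limit of this assay and not a number. Among the compounds with values here, it differs from compound 2 in more than one place, so it offers no single step to read.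

Within the data shown here, compound 2 holds one of only two numbers in the set, and compound 3 is its nearest neighbour. The two are not separable: a 1.5-fold higher number from compound 2 to compound 3 (0.18 log units; within the scatter).

The next compound is compound 4 `CSc1ccc(C2=C(c3ccc(C)c(C)c3)C(=O)N3CCCC3C2)cc1`, which has methyl in place of methoxy on an aromatic carbon of compound 2, ortho to a methyl group (methyl in place of methoxy on an aromatic carbon). Cut one bond further out, this reads 4-methoxy-3-methylphenyl to 3,4-dimethylphenyl.

Among the measured compounds shown here, only one measured step bears on this change. It replaces the same 4-methoxy-3-methylphenyl group, and a 1.5-fold higher number from compound 2 to compound 3 (0.18 log units; within the scatter). One step is thin support, but it gives no reason to expect a large shift in this assay. The expected result is a 1.3-fold higher number from compound 2 to compound 4 (0.10 log units; within the scatter), which means no change beyond the scatter and no preferred direction. For compound 4 the estimated value is 250 nM, with an expected range from 80 nM to 800 nM.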

Compound 4, concentration for 50% growth inhibition: 800 nM
Compound 4: middle estimate off by 3.2-fold (0.51 log units), on the low side; low and high end bracket the measured number.
By their numbers in this assay, from the lowest: compounds 2 and 3 (each within the scatter of the next); then compound 4. At a limit, above all of these: compound 1.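

In this assay, within the data shown here, putting methyl in place of methoxy on the 4-methoxy-3-methylphenyl group gives the first step in this set that lies beyond the scatter: a 4.0-fold higher number from compound 2 to compound 4 (0.60 log units; beyond the scatter). The 3,4-dimethylphenyl group also separates from the 3,4-difluorophenyl group, with a 2.7-fold higher number from compound 3 to compound 4 (0.43 log units; beyond the scatter), whereas the other replacement of the 4-methoxy-3-methylphenyl group stays unresolved, with a 1.5-fold higher number from compound 2 to compound 3 (0.18 log units; within the scatter); this position therefore does respond to the group placed there, although both steps beyond the scatter are modest and compound 4 stands above compounds 2 and 3, which cannot be ordered. Nothing available here gives a reason for this shift.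

Among these compounds, only three groups can be compared at this position, so it remains open how an amine, a carboxylic acid or a longer chain in the place of the methoxy would read in this assay. Compound 1 gives > 100000 nM, which is a limit and not a number, and it differs from compound 2 in more than one place, so the change that separates them cannot be assigned to any one part of the structure.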